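The compounds below may be only part of what the source reports. "The series", "measured", "known", "first", "only" and "open" are said of these compounds alone.

Measured compounds:
- compound 1, `CCC[C@@H](O)C1=C(Br)/C(=C/I)OC1=O`: 4.1 ug/mL
- compound 2, `CCCCC1=C(Br)C(=C(Br)Br)OC1=O`: > 20 ug/mL

In a functional assay on KB cells (Homo sapiens) for cytotoxicity (a higher number here means that more compound is needed for the effect, a lower number that less compound is needed), compound 1 gives 4.1 ug/mL. Within the data shown here, this is the only number reported; the one further value is a limit. For compound 2 the result in this assay is given only as a limit, > 20 ug/mL, not as a number. Compound 1 therefore stands at the sole measured point, with compound 2 sitting at the limit of > 20 ug/mL in this assay, at which 1 of the 2 values shown sits.

The unmeasured compound 3, `CCC[C@@H](O)C1=C(Br)/C(=C/Cl)OC1=O`, differs from compound 1 by chloro in place of iodo on a double-bonded chain carbon bound to a double-bonded ring carbon. Among the measured compounds shown here, no step between measured compounds is available, so the effect of this exchange cannot be read from the data. Chloro in place of iodo on a double-bonded chain carbon bound to a double-bonded ring carbon is a small change on the shared core, and the step is expected to be modest, more likely toward a higher concentration than toward a lower one, though it may stay within the scatter.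

For compound 3 the estimated value in this assay is 8 ug/mL, with a range from 2.5 ug/mL to 25 ug/mL, which is expected to mean a step of a 2.0-fold higher number from compound 1 to compound 3 (0.29 log units; within the scatter).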

Compound 3, concentration for half-maximal effect: 1.2 ug/mL
Beside the measured number, compound 3's estimate is 6.7-fold (0.82 log units) above it; measured number below the stated range.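

In this assay, among these compounds, chloro in place of iodo on a double-bonded chain carbon bound to a double-bonded ring carbon gives a 3.4-fold lower number from compound 1 to compound 3 (0.53 log units; beyond the scatter), the only step on the shared core that can be read. This shows that the position is not indifferent to which halogen it carries: exchanging one heavy atom for another, with no change in ring, charge or the count of hydrogen-bond donors and acceptors, moves the result beyond the usual scatter, toward less compound being needed for the effect. Nothing shown here accounts for the direction or size of this step.

As far as these compounds go, a single step between iodo and chloro sets no trend, so it remains open whether fluoro or a methyl group on that same carbon would carry the change further, reverse it or leave the result unchanged. Compound 2 gives > 20 ug/mL, which is a limit of the assay and not a number, and it differs from compound 1 in more than one place, so it adds no readable step and leaves the contribution of the other parts of the core open.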